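Hydroxyphenyl swaps on two related dienone cores

The compounds below may be only part of what the source reports. "The series", "measured", "known", "first", "only" and "open" are said of these compounds alone.

The measured compounds, in a functional assay, with a stated time of 30 min; a higher number here means a weaker inhibitor, a lower number a stronger inhibitor:
compound 1, `O=C(/C=C/c1ccccc1O)CC(=O)/C=C/c1cccc(O)c1O`, gives 23000 nM;
compound 2, `O=C(/C=C/c1cccc(O)c1)CC(=O)/C=C/c1cccc(O)c1O`, gives 29000 nM;
compound 3, `O=C(/C=C/c1ccc(O)c(O)c1)/C=C/c1ccccc1O`, gives 62000 nM.

Compounds 1 and 2 share one core and differ in a single place, (3-hydroxyphenyl in place of 2-hydroxyphenyl on a double-bonded chain carbon bound to a double-bonded chain carbon). The step measured for that change is a 1.3-fold higher number from compound 1 to compound 2 (0.10 log units; within the scatter), so the two values give no ground to order them. Compound 3 carries a different core; how its core differs from that of compound 1 is not broken down here. Its number in this assay stands above those of compound 1 and compound 2, both gaps being beyond the scatter.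

Compound 4, `O=C(/C=C/c1cccc(O)c1)/C=C/c1ccc(O)c(O)c1`, is not yet measured. It differs from compound 3 as 3-hydroxyphenyl in place of 2-hydroxyphenyl on a double-bonded chain carbon bound to a double-bonded chain carbon, which is the same change that separates compound 1 from compound 2, made on the same kind of position on the chain. Since that change produced a 1.3-fold higher number from compound 1 to compound 2 (0.10 log units; within the scatter), the step expected in this assay is a 1.2-fold higher number from compound 3 to compound 4 (0.06 log units; within the scatter), resting on one prior pair only, on a different core. Compound 4 is therefore estimated at 72000 nM, expected between 36000 nM and 145000 nM.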

Compound 4, half-maximal inhibitory concentration: 71000 nM
For compound 4 the middle estimate is 1.0-fold (0.01 log units) above the measured one; measured number inside the range.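

In this assay, 3-hydroxyphenyl in place of 2-hydroxyphenyl on a double-bonded chain carbon bound to a double-bonded chain carbon gives a 1.1-fold higher number from compound 3 to compound 4 (0.06 log units; within the scatter), so the values give no ground to order compound 3 and compound 4. The same change gives steps on the two cores that cannot be told apart: the same change on two cores in this assay, a 1.3-fold higher number (0.10 log units; within the scatter) from compound 1 to compound 2 and a 1.1-fold higher number (0.06 log units; within the scatter) from compound 3 to compound 4, 1.1-fold (0.04 log units) apart, within the scatter of two such steps. Among the compounds shown here, this shows that, across these two pairs, the swap leaves the number within the scatter on either core; it does not show that the swap has any real effect of its own, and with only two pairs it does not show that the same would hold on any further core.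

The compounds shown leave open what the core alone contributes, since no pair here differs only in the core. They also leave open whether a methoxy group or an amine in place of the hydroxyl group on these rings would shift the number in this assay on either core.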